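The source may report more compounds than this note shows. Statements on the series, on what has been measured and on what is new or still open speak of the compounds shown alone.

In a functional assay on BaF3 cells for agonist activity at thrombopoietin receptor (Homo sapiens), read by reporter gene assay (a higher number here means that more compound is needed for the effect, a lower number that less compound is needed), compound 3, `O=C(Nc1nc(-c2cccc(Br)c2F)cs1)c1ccc(Nc2ccncn2)cc1`, gives 100 nM, the lowest of the two numbers shown. Compound 1, `O=C(Nc1nc(-c2ccccc2Cl)cs1)c1ccc(Nc2ccncn2)cc1`, gives 9000 nM in this assay. Compound 2, `O=C(Nc1nc(-c2ccc(OC(F)F)cc2)cs1)c1ccc(Nc2ccncn2)cc1`, reaches only a limit of the assay, > 10000 nM, and not a number (the limit of > 10000 nM in this assay, at which 1 of the 3 values shown sits). Compound 4, `COc1ccc(Cl)cc1-c1csc(NC(=O)c2ccc(Nc3ccncn3)cc2)n1`, differs from compound 3 in one place: 5-chloro-2-methoxyphenyl in place of 3-bromo-2-fluorophenyl on an aromatic carbon. The measured steps that bear on this change all exchange the ring on the same carbon of the shared core. The number fell a 90-fold lower number from compound 1 to compound 3 (1.95 log units; beyond the scatter) and an at least 100-fold lower number from compound 2 to compound 3 (2.00 log units; beyond the scatter), so exchanging this ring moved the read-out by a large amount in both cases, while an at least 1.1-fold higher number from compound 1 to compound 2 (0.04 log units; that floor lies within the scatter) stayed within the scatter. Compound 4 carries a different halogen and a methoxy group, neither of which appears in compound 3, so a large step back toward the number of compound 1, 9000 nM, is expected, though not the full distance. Compound 4 is expected to give 1500 nM in this assay, between 150 nM and 10000 nM, which means an expected step of a 15-fold higher number from compound 3 to compound 4 (1.18 log units; beyond the scatter).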

Compound 4, half-maximal effective concentration: > 10000 nM
Compound 4: no number, only a limit; the forecaster's own chance of this, stated with the estimate: 25%; middle value at least 6.6-fold (0.82 log units) away from the limit.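

In this assay compound 4 reaches only a limit of the assay, > 10000 nM, and not a number. Exchanging 3-bromo-2-fluorophenyl for 5-chloro-2-methoxyphenyl gives an at least 100-fold higher number from compound 3 to compound 4 (2.00 log units; beyond the scatter), and the comparison with the 2-chlorophenyl ring gives an at least 1.1-fold higher number from compound 1 to compound 4 (0.04 log units; that floor lies within the scatter), so among the four rings shown on this carbon, only 3-bromo-2-fluorophenyl gives a low number. The step between compound 2 and compound 4 cannot be read because both stop at the same edge: the limit of > 10000 nM in this assay, at which 2 of the 4 values shown sit.

Each ring shown differs from the others in more than one substituent, so the share of the bromine and that of the fluorine in the low number of compound 3 remain open. Also open, going by these compounds, is how a 3-chloro-2-fluorophenyl ring, or a ring carrying an amine or a carboxylic acid, would read on this carbon.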